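Nitro for Hydroxy on a Weakly Cytotoxic Core

The compounds below may be only part of what the source reports. "The series", "measured", "known", "first", "only" and "open" are said of these compounds alone.

Measured so far in a functional assay on MCF7 cells (Homo sapiens) for cytotoxicity, read by MTT assay, with a stated time of 48 h; on this read-out higher numbers stand for weaker inhibition and lower numbers for stronger inhibition:
compound 1 `COc1ccc(C(=O)C2Sc3nnc(-c4cc(OC)c(OC)c(OC)c4)n3NC2c2ccco2)cc1`: > 100000 nM, a limit of the assay rather than a number
compound 2 `COc1cc(-c2nnc3n2NC(c2ccco2)C(C(=O)c2cccc(Br)c2)S3)cc(OC)c1OC`: 91800 nM
compound 3 `COc1cc(-c2nnc3n2NC(c2ccco2)C(C(=O)c2ccc(O)cc2)S3)cc(OC)c1OC`: 88900 nM

All three compounds share one core and differ only in the aryl group on the carbonyl carbon. Compound 3 and compound 2 sit within the scatter of each other, as the step of a 1.0-fold lower number from compound 2 to compound 3 (0.01 log units; within the scatter) shows. Compound 1 gives only a limit in this assay: the limit of > 100000 nM in this assay, at which 1 of the 3 values shown sits. The steps of an at least 1.0-fold lower number from compound 1 to compound 2 (0.03 log units; that floor lies within the scatter) and an at least 1.1-fold lower number from compound 1 to compound 3 (0.05 log units; that floor lies within the scatter) therefore set floors that also lie within the scatter.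

The unmeasured compound 4 `COc1cc(-c2nnc3n2NC(c2ccco2)C(C(=O)c2ccc([N+](=O)[O-])cc2)S3)cc(OC)c1OC` differs from compound 3 at the same aryl group: nitro in place of hydroxy on an aromatic carbon.

The three measured steps all change this aryl group, and none of them moved the number in this assay beyond the scatter. On that basis, the change from 4-hydroxyphenyl to 4-nitrophenyl is expected to leave the number roughly where it is, so the expected step of a 1.0-fold higher number from compound 3 to compound 4 (0.01 log units; within the scatter) is no step beyond the scatter. Compound 4 is estimated to give 90000 nM in this assay, within a range from 40000 nM to 200000 nM, with a fair chance that only a limit is reported.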

Compound 4, half-maximal inhibitory concentration: > 100000 nM
Compound 4 gave a limit, no number (the forecaster's own chance of this, stated with the estimate: 35%); at least 1.1-fold (0.04 log units) between middle value and limit.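

Nitro joins methoxy and hydroxy as a third group on this aromatic carbon, and in this assay compound 4 gives > 100000 nM, which is a limit and not a number. This sets only floors on the change, and the steps of an at least 1.1-fold higher number from compound 3 to compound 4 (0.05 log units; that floor lies within the scatter) and an at least 1.0-fold higher number from compound 2 to compound 4 (0.03 log units; that floor lies within the scatter) do not show that compound 4 differs from either compound; the step between compound 1 and compound 4 cannot be read, as both values are limits. Nitro therefore brings no stronger inhibition on this aryl group, and more of the series now rests at the ceiling of the read-out: the limit of > 100000 nM in this assay, at which 2 of the 4 values shown sit.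

As far as these compounds go, how far the true values of compound 1 and compound 4 lie beyond that limit stays unknown, so a real loss of activity on going from hydroxy to nitro cannot be ruled out. Also open, from the compounds shown here alone, is whether an amine or a carboxylic acid on this aromatic carbon would bring the number clearly below those seen here, or whether only a change elsewhere on the shared core could do so.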